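Amide series: nitro for amino on the benzamide

The compounds below may be only part of what the source reports. "The series", "measured", "known", "first", "only" and "open" are said of these compounds alone.

Working notes. The shared core of compound 1 `CCc1cc(S(=O)(=O)N2C[C@H](c3ccccc3)NC2=O)ccc1NC(=O)OC` carries a methoxy carbonyl; in a functional assay on HCT-116 cells (Homo sapiens) for cytotoxicity, read by MTT assay (on this read-out higher numbers stand for weaker inhibition and lower numbers for stronger inhibition), compound 1 gives 200 nM. Within the data shown here, compound 3 `CCc1cc(S(=O)(=O)N2C[C@H](c3ccccc3)NC2=O)ccc1NC(=O)NC1CCCCC1` differs only in that cyclohexylamino replaces methoxy on the carbonyl carbon, and in this assay compound 3 gives 300 nM; the step of a 1.5-fold higher number from compound 1 to compound 3 (0.18 log units; within the scatter) is the only measured step in the set. Compound 2 `Cc1cc(S(=O)(=O)N2C(=O)N[C@@H](c3ccccc3)C2C)ccc1NC(=O)c1ccc(N)cc1` belongs to a second core and carries a (4-aminophenyl)carbonyl on the aniline nitrogen. In this assay, among the measured compounds shown here, compound 2 gives > 10000 nM, which is a limit and not a number, the only one among the three values (the limit of > 10000 nM in this assay, at which 1 of the 3 values shown sits). Compound 2 therefore stands at the weak edge of what is shown, with no number to place it against compound 1 or compound 3.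

Compound 4 `Cc1cc(S(=O)(=O)N2C(=O)N[C@@H](c3ccccc3)C2C)ccc1NC(=O)c1ccc([N+](=O)[O-])cc1` is the next member, with the change (nitro in place of amino on an aromatic carbon). For the measured compounds named here, no measured step touches this position or this core: the step from compound 1 to compound 3 concerns a carbamate-to-urea exchange on the other core and gives no guidance on an aryl amino to nitro swap. The expectation thus rests on compound 2 alone, whose limit of > 10000 nM suggests weak inhibition on this core. For compound 4 the estimate is 10000 nM, within 2000 nM to 30000 nM, with the expected step of a number no higher from compound 2 to compound 4 (the limit leaves the size open) treated as no change beyond the scatter, and a real chance that only a limit is again reported.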

Compound 4, half-maximal inhibitory concentration: > 10000 nM
Compound 4: no number, only a limit; the forecaster's own chance of this, stated with the estimate: 65%; the middle value lies on the limit itself.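

Compound 2 and compound 4 both return only a limit in this assay, so the exchange of amino for nitro gives no readable step: the limit of > 10000 nM in this assay, at which 2 of the 4 values shown sit.

The compounds shown leave open whether the 4-aminophenyl and 4-nitrophenyl amides differ at all in this assay, since neither has a number on this core.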